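The source may report more compounds than this note shows. Statements on the series, on what has been measured and on what is new or still open speak of the compounds shown alone.

Measured in an ADME assay on the whole organism for inhibition, with Oryza sativa as the target, with a stated time of 4 days; a lower number here means a stronger inhibitor, a higher number a weaker inhibitor:
- compound 1 `CC(C)N(c1nc(Cl)nc(N[C@@H](C)c2ccccc2)n1)C(C)C` gives 372 nM
- compound 2 `C[C@H](Nc1nc(Cl)nc(NC(C)(C)C)n1)c1ccccc1` gives 3310 nM
- compound 3 `CC[C@@H](C)Nc1nc(Cl)nc(N[C@H](C)c2ccccc2)n1` gives 8320 nM

Compound 3 has the highest number of the three, beyond the scatter from both others. Compound 4 `CC[C@@H](C)Nc1nc(Cl)nc(N[C@@H](C)c2ccccc2)n1` is its stereoisomer: the two compounds have the same atoms and bonds and differ only in configuration as drawn: 1 of 2 stereo elements differ; a stereocentre at a saturated chain carbon is drawn R in compound 3 and S in compound 4. Within the data shown here, no measured pair isolates a change of configuration. Among the measured compounds shown here, the only measured step, an 8.9-fold higher number from compound 1 to compound 2 (0.95 log units; beyond the scatter), is a swap of amino groups with configuration held, so it bears only indirectly, as a sign that this series can move by a modest amount on a single change. Compound 1 at 372 nM and compound 2 at 3310 nM share the configuration of compound 4 at the altered stereocentre, and both read lower than compound 3. Their other amino group differs from that of compound 3, however, so this is weak evidence on direction. A lower number is expected, by less than the measured step. The expected change is a 2.8-fold lower number from compound 3 to compound 4 (0.44 log units; beyond the scatter) as a rough estimate. For compound 4 the estimate is 3000 nM, with an expected range from 700 nM to 12000 nM at its ends.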

Compound 4, half-maximal inhibitory concentration: 9770 nM
Compound 4: middle estimate off by 3.3-fold (0.51 log units), on the low side, and the stated range covers the measured number.
By their numbers in this assay, from the lowest: compound 1; then compound 2; then compounds 3 and 4 (each within the scatter of the next).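

In this assay, among these compounds, the first pair to isolate configuration gives a 1.2-fold higher number from compound 3 to compound 4 (0.07 log units; within the scatter), so inverting this stereocentre at a saturated chain carbon leaves the number within the scatter, with sec-butyl as the other amine substituent. This single change is what makes the pair informative about stereochemistry: the fact that compounds 3 and 4 differ only in the configuration as drawn. Among the compounds shown here, with the configuration at that centre shared, the amino group is the place that moves the number, through a 3.0-fold higher number from compound 2 to compound 4 (0.47 log units; beyond the scatter) for sec-butyl in place of tert-butyl and through a 26-fold higher number from compound 1 to compound 4 (1.42 log units; beyond the scatter) for (sec-butyl)amino in place of diisopropylamino, so the series so far responds to this amino group rather than to the inversion.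

On these data alone, it remains open whether the same inversion would stay within the scatter with diisopropylamino or tert-butyl as the partner group, and whether the second stereocentre behaves in the same way. Also open, as far as these compounds go, is how the number would respond to a cyclic amine such as piperidine or to a longer chain such as n-hexyl in this amino position.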